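Chloro in place of nitro on the sulfonyl aryl ring

The source may report more compounds than this note shows. Statements on the series, on what has been measured and on what is new or still open speak of the compounds shown alone.

Compound 3 `CC1CCc2ccccc2N1S(=O)(=O)c1ccc([N+](=O)[O-])cc1` stands highest of the three compounds tested in an ADME assay on L6 cells (Rattus norvegicus) for cytotoxicity (a higher number here means a weaker inhibitor, a lower number a stronger inhibitor), where compound 3 gives 248000 nM. Compound 1 `Cc1ccc(S(=O)(=O)N2c3ccccc3CCC2C)cc1` gives 4900 nM and compound 2 `COc1ccc(S(=O)(=O)N2c3ccccc3CCC2C)cc1` gives 5990 nM. Compound 4 `CC1CCc2ccccc2N1S(=O)(=O)c1ccc(Cl)cc1` differs from compound 3 by chloro in place of nitro on an aromatic carbon. For the measured compounds named here, two measured steps bear on this: a 51-fold higher number from compound 1 to compound 3 (1.70 log units; beyond the scatter) and a 41-fold higher number from compound 2 to compound 3 (1.62 log units; beyond the scatter), both large, both in the same direction. Going by the values given here, no measured step involves a chloro group, so the effect of its entry is unknown. Because undoing the nitro undoes the change behind a 51-fold higher number from compound 1 to compound 3 (1.70 log units; beyond the scatter), a decrease is expected, though its size is uncertain; compound 4 is estimated at 25000 nM with a range from 4000 nM to 150000 nM, a step of a 9.9-fold lower number from compound 3 to compound 4 (1.00 log units; beyond the scatter) expected.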

Compound 4, half-maximal inhibitory concentration: 20500 nM
For compound 4 the middle estimate is 1.2-fold (0.09 log units) above the measured one; low and high end bracket the measured number.
By their numbers in this assay, from the lowest: compounds 1 and 2 (each within the scatter of the next); then compound 4; then compound 3.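

In this assay, chloro in place of nitro gives a 12-fold lower number from compound 3 to compound 4 (1.08 log units; beyond the scatter), yet it does not reach the level of the methyl and methoxy compounds, leaving a 4.2-fold higher number from compound 1 to compound 4 (0.62 log units; beyond the scatter) and a 3.4-fold higher number from compound 2 to compound 4 (0.53 log units; beyond the scatter). This position therefore shows three levels rather than two, with chloro lying between nitro and the methyl and methoxy pair. Nothing available explains this order. Where an amine, a carboxylic acid or a longer chain would fall at this position remains open. So does whether the same order holds with changes elsewhere on the shared core.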